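The source may hold more compounds than are shown below. What is called first, only, known or untested is meant among the compounds shown, and "the series" means these compounds.

Compound 1 `CC[C@H](C1CC1)n1c(=O)c(C)nc2c(-c3ccc(Cl)cc3Cl)ccnc21` gives 8.2 nM in a functional assay for antagonist activity at corticotropin-releasing factor receptor 1 (Rattus norvegicus); on this read-out higher numbers stand for weaker inhibition and lower numbers for stronger inhibition. Compound 2 `CC[C@@H](C1CC1)n1c(=O)c(C)nc2c(-c3ccc(Cl)cc3Cl)ccnc21` gives 7.4 nM in this assay.

Going by the values given here, compound 1 and compound 2 lie within the scatter of each other, the only measured step being a 1.1-fold lower number from compound 1 to compound 2 (0.04 log units; within the scatter), which reflects (the fact that compounds 1 and 2 differ only in the configuration as drawn). Compound 3 `CC[C@H](C1CC1)n1c(=O)c(C)nc2c(-c3ccc(OC)nc3C)ccnc21` differs from compound 1 by 6-methoxy-2-methylpyridin-3-yl in place of 2,4-dichlorophenyl on an aromatic carbon. Among the compounds with values here, no measured step touches this aryl exchange, so the stereo step gives no guide to size or direction, and the expectation rests on compound 1 alone with a wide range. Compound 3 is estimated at 15 nM, expected to fall between 3 nM and 80 nM. The expected step is a 1.8-fold higher number from compound 1 to compound 3 (0.26 log units; within the scatter), which may not exceed the scatter.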

Compound 3, half-maximal inhibitory concentration: 76 nM
Compound 3: the middle estimate sits 5.1-fold (0.70 log units) below what was measured; measured number inside the range.
By their numbers in this assay, from the lowest: compounds 2 and 1 (each within the scatter of the next); then compound 3.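

In this assay, the aryl group on this aromatic carbon affects the read-out: 6-methoxy-2-methylpyridin-3-yl in place of 2,4-dichlorophenyl gives a 9.3-fold higher number from compound 1 to compound 3 (0.97 log units; beyond the scatter). Going by these compounds alone, the configuration change gave only a 1.1-fold lower number from compound 1 to compound 2 (0.04 log units; within the scatter), so this is the first step beyond the scatter. No recorded fact bears on the reason for this step.

As far as these compounds go, the exchange alters the ring nitrogen, the methoxy, the methyl and both chlorines together, so the part responsible remains open. A 4-methoxy-2-methylphenyl group at this place would test the ring nitrogen alone.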